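The source may hold more compounds than are shown below. What is called first, only, known or untested is meant among the compounds shown, and "the series" means these compounds.

The measured compounds:

Compound 1, `CC(c1ccc(-c2ccccc2)c(F)c1)c1nnc2n1N=C(c1ccc(Cl)cc1)CS2`: 6100 nM
Compound 2, `COc1ccc(C2=Nn3c(nnc3C(C)c3ccc(-c4ccccc4)c(F)c3)SC2)cc1`: 5800 nM

Both compounds were tested in a functional assay on Mahlavu cells (Homo sapiens) for inhibition, read by sulforhodamine B assay, with a stated time of 72 h; a lower number here means a stronger inhibitor, a higher number a weaker inhibitor. Going by the values given here, compound 2 gives 5800 nM and compound 1 gives 6100 nM, so compound 2 stands level with its only neighbour: the step of a 1.1-fold lower number from compound 1 to compound 2 (0.02 log units; within the scatter) is within the scatter, and the two numbers cannot be told apart.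

Compound 3, `CC(c1ccc(-c2ccccc2)c(F)c1)c1nnc2n1N=C(c1ccc(Br)cc1)CS2`, has not yet been measured. It differs from compound 2 in one place: bromo in place of methoxy on an aromatic carbon. Among the compounds with values here, the only measured step that bears on this change is a 1.1-fold lower number from compound 1 to compound 2 (0.02 log units; within the scatter), which swapped a halogen for the methoxy group and left the number essentially unchanged. Going back from methoxy to a halogen, here bromo, is therefore expected to move the number no further than the scatter allows, in no clear direction. Compound 3 is expected to give about 6000 nM in this assay, with a range from 3000 nM to 12000 nM. The expected step of a 1.0-fold higher number from compound 2 to compound 3 (0.01 log units; within the scatter) amounts to nothing beyond the scatter.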

Compound 3, half-maximal inhibitory concentration: 6200 nM
Beside the measured number, compound 3's estimate is 1.0-fold (0.01 log units) below it; low and high end bracket the measured number.
By their numbers in this assay, from the lowest: compounds 2, 1 and 3 (each within the scatter of the next).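

With bromo now on this aromatic carbon, para to a large group, three different groups have been read at one place in this assay, and none of them separates from the others. The methoxy compound and the new one give a 1.1-fold higher number from compound 2 to compound 3 (0.03 log units; within the scatter), while the two halogens give a 1.0-fold higher number from compound 1 to compound 3 (0.01 log units; within the scatter), so both comparisons stay within the scatter. The earlier pair held only one halogen and methoxy, whereas the series now adds a second halogen and a direct comparison of chloro with bromo, and the number still does not respond to the swap; no separate measurement is available to explain this flat reading.

The compounds shown leave open whether a group of a different kind at this same place, such as an amine or a carboxylic acid, would shift the number beyond the scatter. They also leave open whether a change elsewhere on the shared core would move it, as all three compounds differ only at this one position.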